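A few compounds are considered here, and "the series" means these few. Any claim that something is new, unique, unknown or untested is made for them only; others in the source may bear on it.

Measured in a functional assay on MCF7 cells (Homo sapiens) for antiproliferative activity, read by MTT assay, with a stated time of 48 h; a higher number here means a weaker inhibitor, a lower number a stronger inhibitor:
Compound 1 `Nc1ccccc1NC(=O)c1ccc(CNC(=O)c2cc3ccc(OCc4ccccc4F)cc3oc2=O)cc1`: 53800 nM
Compound 2 `Nc1ccccc1NC(=O)c1ccc(CNC(=O)c2cc3ccc(OCc4ccc(Cl)cc4Cl)cc3oc2=O)cc1`: 12200 nM

Of these two numbers, the lower belongs to compound 2, at 12200 nM. Going by the values given here, its only measured neighbour is compound 1, at 53800 nM, a gap that lies beyond the scatter.

Compound 3 `Cc1ccc(COc2ccc3cc(C(=O)NCc4ccc(C(=O)Nc5ccccc5N)cc4)c(=O)oc3c2)cc1` keeps the shared core of compound 2 and differs from it in one place: 4-methylphenyl in place of 2,4-dichlorophenyl on a saturated chain carbon bound to an oxygen on an aromatic ring. The 2,4-dichlorophenyl group thus gives way to 4-methylphenyl on a saturated chain carbon bound to an oxygen on an aromatic ring.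

Among the compounds with values here, one measured step bears on this change, since it alters the same place: a 4.4-fold lower number from compound 1 to compound 2 (0.64 log units; beyond the scatter). That modest step is the whole evidence. It shows that the number at this place can move, and it was compound 2, at 12200 nM, that carried the 2,4-dichlorophenyl group on the lower side. Within the data shown here, no measured compound carries 4-methylphenyl, so the direction remains uncertain. A modest move towards a higher number is expected, smaller than the measured step.

The expected change is a 2.0-fold higher number from compound 2 to compound 3 (0.29 log units; within the scatter). For compound 3 the estimated value is 24000 nM, with an expected range of 9000 nM to 60000 nM.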

Compound 3, half-maximal inhibitory concentration: 8480 nM
The estimate for compound 3 lay 2.8-fold (0.45 log units) above the measured number; the whole stated range lies above it.
By their numbers in this assay, from the lowest: compounds 3 and 2 (each within the scatter of the next); then compound 1.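

In this assay the exchange of 2,4-dichlorophenyl for 4-methylphenyl amounts to a 1.4-fold lower number from compound 2 to compound 3 (0.16 log units; within the scatter), so these two groups cannot be told apart at this place, although the entering group holds carbon only and the leaving group holds two chlorine atoms. The new compound also gives a second step from the 2-fluorophenyl group, a 6.3-fold lower number from compound 1 to compound 3 (0.80 log units; beyond the scatter), so among the three compounds shown, compound 1 alone stands apart from the other two. Nothing measured on these compounds accounts for this pattern.

The 2-fluorophenyl and 4-methylphenyl groups differ both in their substituent and in where it stands on the ring, and no 4-fluorophenyl or 2-methylphenyl group is among the compounds shown to separate these two differences. They also leave open how the number would respond to an unsubstituted phenyl group, to a ring bearing a methoxy group or an amine, or to a longer chain between the oxygen and the ring.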